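The source may hold more compounds than are shown below. What is called first, only, known or untested is meant among the compounds shown, and "the series" means these compounds.

Measured so far in a functional assay on A-375 cells (Homo sapiens) for cytotoxicity, read by sulforhodamine B assay, with a stated time of 48 h; on this read-out higher numbers stand for weaker inhibition and lower numbers for stronger inhibition:
- compound 1 `O=[N+]([O-])c1ccc(-c2nccn2S(=O)(=O)c2ccccc2)cc1`: > 10000 nM
- compound 2 `COc1ccc(C(=O)n2ccnc2-c2ccccc2)cc1`: > 10000 nM
- compound 3 `COc1cc(C(=O)n2ccnc2-c2ccccc2)cc(OC)c1OC`: > 10000 nM

Each of these entries is a limit of the assay and not a number. Compound 1 stands at > 10000 nM, which is a limit. It shares that position with compound 2 and compound 3, as the summary shows: the limit of > 10000 nM in this assay, at which 3 of the 3 values shown sit. The compounds therefore cannot be ranked against one another, and compound 1 offers no exact starting number.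

The next compound is compound 4 `O=S(=O)(c1ccccc1)n1ccnc1-c1ccccc1`. It keeps the core of compound 1 and differs in one place, with hydrogen in place of nitro on an aromatic carbon, para to a large group (hydrogen in place of nitro on an aromatic carbon). Within the data shown here, no pair of measured compounds shows what this change does in this assay, so the expectation is a cautious one. It rests on compound 1 and its limit of > 10000 nM. The expected change is a step that the limit leaves unreadable from compound 1 to compound 4, which means nothing beyond the usual scatter in either direction. Compound 4 is estimated at 12000 nM, with an expected range from 4000 nM to 30000 nM. A report of only a limit would be the most likely outcome.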

Compound 4, half-maximal inhibitory concentration: > 10000 nM
Compound 4 gave a limit, no number; the forecaster's own chance of this, stated with the estimate: 85%; the middle value does not contradict the limit.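

Compound 4, like compound 1, gives a limit and not a number, so no step can be read between these two compounds, and all the compounds shown sit at the same limit: the limit of > 10000 nM in this assay, at which 4 of the 4 values shown sit. In this assay the compounds shown leave open whether any change to these structures would give a measurable value.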